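The source may report more compounds than this note shows. Statements on the series, on what has been measured and on what is new or still open speak of the compounds shown alone.

Measured compounds:
Compound 1 `CNC(=O)c1cc(Oc2ccc(NC(=O)c3cc(-c4ccc(C)cc4)ncn3)cc2)ccn1`: > 100000 nM
Compound 2 `CNC(=O)c1cc(Oc2ccc(NC(=O)c3nccc(-c4ccc([N+](=O)[O-])cc4)n3)cc2)ccn1`: > 100000 nM
Compound 3 `CNC(=O)c1cc(Oc2ccc(NC(=O)c3nccc(-c4ccc(OC)cc4)n3)cc2F)ccn1`: 24300 nM

In a functional assay on PC-3 cells (Homo sapiens) for cytotoxicity, read by MTT assay, with a stated time of 72 h (on this read-out lower numbers stand for stronger inhibition and higher numbers for weaker inhibition), compound 1 gives > 100000 nM, which is a limit of the assay and not a number. Compound 2 gives > 100000 nM, which is also a limit. These two share one position on the scale: the limit of > 100000 nM in this assay, at which 2 of the 3 values shown sit. Compound 3 goes against this pattern, giving a true number of 24300 nM. Among the measured compounds shown here, no two measured compounds differ in only one place, so the data show no direct effect of a single change.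

The next compound, compound 4 `CNC(=O)c1cc(Oc2ccc(NC(=O)c3cc(-c4ccccc4)ncn3)cc2)ccn1`, keeps the core of compound 1 and makes one small edit. It has hydrogen in place of methyl on an aromatic carbon, so 4-methylphenyl becomes phenyl (hydrogen in place of methyl on an aromatic carbon). The change sits on a six-membered aromatic ring of carbon only, para to a large group.

For the measured compounds named here, because compound 1 gives only the limit > 100000 nM there is no number to move from, and no measured pair suggests a direction. The expectation is therefore no change beyond the usual scatter in this assay, and the assay may well report a limit again. The expected size is a number no higher from compound 1 to compound 4 (the limit leaves the size open), which stays within that scatter.

For compound 4 the estimated value is 100000 nM, with an expected range from 30000 nM to 300000 nM.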

Compound 4, half-maximal inhibitory concentration: 44200 nM
Compound 4: the middle estimate sits 2.3-fold (0.35 log units) above what was measured, within the range that was stated.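

In this assay compound 1 gives > 100000 nM, which is a limit of the assay and not a number. Among the compounds shown here, compound 4 gives 44200 nM, a true number, and replacing 4-methylphenyl with phenyl provides the first comparison here between two compounds that differ in only one place, showing an at least 2.2-fold lower number from compound 1 to compound 4 (0.35 log units; beyond the scatter). This shows that a change at this place on the ring can bring a compound off a shared position on the scale, with the printed size serving only as a floor for the full step: the limit of > 100000 nM in this assay, at which 2 of the 4 values shown sit.

From the compounds shown here alone, with only methyl and hydrogen compared at this place, it remains open what a chlorine atom, an amine or a carboxylic acid there would do to the number. Going by these compounds, it is also open whether hydrogen in place of methyl would give a step in the same direction on another core, such as that of compound 3, whose ring carries a methoxy group and whose value in this assay is 24300 nM.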